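The compounds below may be only part of what the source reports. "The series", "measured", "known", "first", "only" and "open" are said of these compounds alone.

Measured so far in a functional assay on U-87MG ATCC cells (Homo sapiens) for cytotoxicity, read by MTT assay, with a stated time of 72 h; on this read-out higher numbers stand for weaker inhibition and lower numbers for stronger inhibition:
- compound 1 `CN(C)CCn1cnnc1-c1cc(Oc2ccc(NC(=O)N/N=C/c3ccc(F)cc3Cl)cc2F)ccn1`: 1210 nM
- compound 2 `CN(C)CCn1cnnc1-c1cc(Oc2ccc(NC(=O)N/N=C/c3ccccc3O[N+](=O)[O-])cc2F)ccn1`: 7150 nM

Going by the values given here, compound 2 gives the highest number of the two in this assay; its nearest neighbour is compound 1, whose number is lower by the single step of a 5.9-fold higher number from compound 1 to compound 2 (0.77 log units; beyond the scatter), a modest change and beyond the scatter. Compound 3 `Cc1cc(/C=N/NC(=O)Nc2ccc(Oc3ccnc(-c4nncn4CCN(C)C)c3)c(F)c2)cc(C)c1O` has not yet been measured. It differs from compound 2 in one place: 4-hydroxy-3,5-dimethylphenyl in place of 2-(nitrooxy)phenyl on a carbon with a double bond to nitrogen. Among the compounds with values here, the one step that bears on this change is the same step from compound 1 to compound 2, which also exchanged the aryl group on a carbon with a double bond to nitrogen and moved the number modestly. Within the data shown here, no step involving the 4-hydroxy-3,5-dimethylphenyl group itself exists. Among the measured compounds shown here, with the only precedent showing that such an exchange shifts the number by a modest amount in either direction, a modest step from compound 2 to compound 3 is expected, more likely towards a lower number, since compound 2 is the highest of the two so far. Compound 3 is therefore estimated at 2800 nM, with a range of 800 nM to 9000 nM. That estimate implies an expected step of a 2.6-fold lower number from compound 2 to compound 3 (0.41 log units; beyond the scatter).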

Compound 3, half-maximal inhibitory concentration: 7710 nM
Compound 3: the middle estimate sits 2.8-fold (0.44 log units) below what was measured; the range from low to high includes it.
By their numbers in this assay, from the lowest: compound 1; then compounds 2 and 3 (each within the scatter of the next).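

In this assay, the 4-hydroxy-3,5-dimethylphenyl and 2-(nitrooxy)phenyl groups on the carbon with a double bond to nitrogen cannot be told apart, with a 1.1-fold higher number from compound 2 to compound 3 (0.03 log units; within the scatter), although the entering group has a hydrogen-bond donor and no nitrogen, while the leaving group has no such donor and does contain nitrogen. Set against the 2-chloro-4-fluorophenyl group, the new group gives a 6.4-fold higher number from compound 1 to compound 3 (0.80 log units; beyond the scatter), so among these three compounds compound 1 alone stands apart at this position, and the earlier step from compound 1 is no longer the effect of a single exchange but is seen with two quite different groups. Nothing measured here accounts for this result.

As far as these compounds go, it remains open whether the chlorine, the fluorine or the two together set compound 1 apart, and how a 4-hydroxyphenyl group without the two methyl groups would read in this assay. A phenyl ring carrying an amine or a carboxylic acid at this place is also untested among the compounds shown, as is whether the same separation would hold on a changed core.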